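The source may report more compounds than this note shows. Statements on the series, on what has been measured and on what is new or still open speak of the compounds shown alone.

Compound 1 (`C=CCc1ccc(OCc2cn(-c3ccc(C#N)cc3)nn2)c(O)c1`) gives 37.5%
Compound 2 (`C=CCc1ccc(OCc2cn(-c3ccc(OC)cc3)nn2)c(O)c1`) gives 31.5%

In a functional assay on SK-N-SH cells (Homo sapiens) for inhibition, read by MTT assay, with a stated time of 72 h, tested at 30 uM (on this read-out higher numbers stand for more inhibition of growth at the one concentration tested and lower numbers for less inhibition of growth), compound 2 stands at 31.5% and cannot be separated from compound 1 at 37.5%. Within the data shown here, the one measured step between them is a number 6 percentage points lower from compound 1 to compound 2 (within the scatter).

The next compound is compound 3 (`C=CCc1ccc(OCc2cn(-c3cccc(C#N)c3)nn2)c(O)c1`), which differs from compound 2 as follows: 3-cyanophenyl in place of 4-methoxyphenyl on an aromatic nitrogen. In words, 3-cyanophenyl stands in place of 4-methoxyphenyl on an aromatic nitrogen. The measured step from compound 1 to compound 2 is the only one that bears on this exchange, since it also links a cyano compound with a methoxy compound. Among the measured compounds shown here, no measured step shows what the place of the cyano group on the ring does. Going by these compounds, no change beyond the scatter is therefore expected in this assay, and the direction stays open. The expected step is a number 3.5 percentage points higher from compound 2 to compound 3 (within the scatter). Compound 3 is estimated at 35%, with an expected range from 24% to 46%.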

Compound 3, percent growth inhibition at one concentration: 21.2%
Compound 3: middle estimate off by 13.8 percentage points, on the high side; measured number outside the range, below it.
By their numbers in this assay, from the lowest: compound 3; then compounds 2 and 1 (each within the scatter of the next).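

In this assay, the place of the nitrile on the phenyl ring matters: 3-cyanophenyl in place of 4-cyanophenyl gives a number 16.3 percentage points lower from compound 1 to compound 3 (beyond the scatter), so two compounds with the same group on different ring carbons can be separated. The exchange of 4-methoxyphenyl for 3-cyanophenyl likewise gives a number 10.3 percentage points lower from compound 2 to compound 3 (beyond the scatter), whereas the 4-cyanophenyl and 4-methoxyphenyl of compound 1 and compound 2 could not be told apart. Nothing available explains these steps.

Going by these compounds, whether a methoxy group or an amine in the ring place that the nitrile holds in compound 3 would give a similar number stays open, so the steps cannot be tied to the ring place in general. On these data alone, with a single concentration, how these compounds compare at other concentrations also stays open.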